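Ring change at the aromatic amine: compound 1 to compound 4

This account rests on a few compounds, and the source may have more. Where it says the series, first, only, none or still open, it means among the compounds named here.

Measured in an assay on isolated protein for inhibition of protein kinase C delta type (Homo sapiens), read by TR-FRET, with a stated time of 2 h; a lower number here means a stronger inhibitor, a higher number a weaker inhibitor:
compound 1 `N#Cc1cnc(NCc2cnccc2C(F)(F)F)cc1NC[C@H]1C[C@H](O)C1` gives > 10000 nM
compound 2 `N#Cc1cnc(NCc2ccccc2C(F)(F)F)cc1N[C@H]1C[C@@H](C(N)=O)C1` gives 4200 nM
compound 3 `COc1ncncc1CNc1cc(N[C@H]2CC[C@@H](O)CC2)c(C#N)cn1` gives 800 nM

Compound 1 stands only at a limit of this assay, (the limit of > 10000 nM in this assay, at which 1 of the 3 values shown sits); no number is known for it. Compounds 2 and 3 give numbers, with compound 3 the lower of the two.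

Compound 4 `CC1(C)C[C@H](Nc2cc(NCc3cnccc3C(F)(F)F)ncc2C#N)CC[C@@H]1O` differs from compound 1 in one place: 4-hydroxy-3,3-dimethylcyclohexyl in place of (3-hydroxycyclobutyl)methyl on a nitrogen on an aromatic ring. For the measured compounds named here, no measured pair shows this change by itself, so its size is not known. Compound 3, which also carries a hydroxylated six-membered ring on the aromatic nitrogen, gives 800 nM, and the expectation is a move to a measurable number.

Compound 4 is expected to reach 2500 nM (600 nM to 10000 nM). This means an estimated step of an at least 4.0-fold lower number from compound 1 to compound 4 (0.60 log units; beyond the scatter) beyond the scatter.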

Compound 4, half-maximal inhibitory concentration: 500 nM
Beside the measured number, compound 4's estimate is 5.0-fold (0.70 log units) above it; the measured number lies below the stated range.
By their numbers in this assay, from the lowest: compounds 4 and 3 (each within the scatter of the next); then compound 2. At a limit, above all of these: compound 1.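

For the compounds shown here, on a nitrogen on an aromatic ring, the change to 4-hydroxy-3,3-dimethylcyclohexyl is the only change here that can be read in one place, and in this assay it gives an at least 20-fold lower number from compound 1 to compound 4 (1.30 log units; beyond the scatter). The group on this nitrogen alone thus takes the shared core from a limit to a measurable number. Compound 1 gives only a limit, not a number, so the step is a lower bound: the limit of > 10000 nM in this assay, at which 1 of the 4 values shown sits.

The compounds shown do not separate the six-membered ring from its two methyl groups. As far as these compounds go, whether an amine or a carboxylic acid in place of the hydroxy group keeps this level also remains open.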